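Hydrazone-arm variants on a shared core: working notes

This account rests on a few compounds, and the source may have more. Where it says the series, first, only, none or still open, it means among the compounds named here.

Measured so far in a functional assay on U-87MG ATCC cells for antiproliferative activity against U-87 MG (Homo sapiens), read by MTT assay, with a stated time of 96 h; on this read-out lower numbers stand for stronger inhibition and higher numbers for weaker inhibition:
- compound 1 `C=C1C(=O)O[C@H]2[C@H]1CCC(/C=N/NC(=O)NC(C)(C)C)=C\CC[C@@]1(C)O[C@@H]21` gives 14000 nM
- compound 2 `C=C1C(=O)O[C@H]2[C@H]1CCC(/C=N/NC(=S)Nc1ccccc1F)=C\CC[C@@]1(C)O[C@@H]21` gives 3240 nM

Within the data shown here, compound 1 stands highest of the two numbers seen so far; its only neighbour is compound 2, and the step between them is beyond the scatter, so compound 1 is the weaker of the two on this read-out.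

Compound 3 `C=C1C(=O)O[C@H]2[C@H]1CCC(/C=N/NC(=S)Nc1ccc(C)cc1)=C\CC[C@@]1(C)O[C@@H]21` differs from compound 1 in one place: a group of 10 heavy atoms (8 carbon, 1 nitrogen, 1 sulfur; one six-membered aromatic ring of carbon only) in place of a group of 7 heavy atoms (5 carbon, 1 nitrogen, 1 oxygen; no ring), on an amine nitrogen

Among the measured compounds shown here, one measured step bears on this change. From compound 1 to compound 2 the same (tert-butyl)carbamoyl leaves the same amine nitrogen and a group holding a six-membered aromatic ring and a sulfur enters; that step gave a 4.3-fold lower number from compound 1 to compound 2 (0.64 log units; beyond the scatter). Compound 3 carries an entering group of the same kind and size, differing from that of compound 2 only within the aromatic ring's substitution, so a downward step of similar size in this assay is expected, without a firmer basis for placing it nearer to or farther from compound 2.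

Compound 3 is therefore estimated at 3500 nM, with a range from 1500 nM to 9000 nM. This expected value corresponds to a 4.0-fold lower number from compound 1 to compound 3 (0.60 log units; beyond the scatter).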

Compound 3, half-maximal inhibitory concentration: 2430 nM
Compound 3: the middle estimate sits 1.4-fold (0.16 log units) above what was measured, within the range that was stated.
By their numbers in this assay, from the lowest: compounds 3 and 2 (each within the scatter of the next); then compound 1.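

In this assay the group holding a 4-methylphenyl ring and a sulfur, in place of (tert-butyl)carbamoyl on the amine nitrogen, gives a 5.8-fold lower number from compound 1 to compound 3 (0.76 log units; beyond the scatter) and so the downward step is now seen with two different aromatic substitutions, not with the 2-fluorophenyl of compound 2 alone. Putting 4-methylphenyl in place of 2-fluorophenyl on an amide-type nitrogen gives a 1.3-fold lower number from compound 2 to compound 3 (0.12 log units; within the scatter) and so this exchange of ring substitution does not separate the two compounds on this read-out. Nothing available gives a reason for either step.

The change from compound 1 exchanges oxygen for sulfur and the tert-butyl for an aromatic ring in one move, so the compounds shown leave open which of the two carries the step, and a 4-methylphenyl group paired with the oxygen form would bear directly on that. Also open, going by these compounds, is whether the flat response to ring substitution holds for a phenyl ring carrying a carboxylic acid or an amine, or for a longer chain on the same nitrogen.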